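This account rests on a few compounds, and the source may have more. Where it says the series, first, only, none or still open, it means among the compounds named here.

Measured in a functional assay on aorta (Rattus norvegicus, strain Wistar); a higher number here means a weaker inhibitor, a lower number a stronger inhibitor:
- compound 1 `CC(=O)c1ccc2c(c1)N(C1=CCCC1=O)CC(C)(C)S2`: 1.45 nM
- compound 2 `CC(=O)Nc1ccc2c(c1)N(C1=CCCC1=O)CC(C)(C)S2`: 6610 nM
- compound 3 `CC1CN(C2=CCCC2=O)c2cc(C(F)(F)F)ccc2S1`: 8.32 nM

Compound 3 holds the second highest of these numbers, lying between compound 1 and compound 2. Compound 4 `CC1(C)CN(C2=CCCC2=O)c2cc(C(F)(F)F)ccc2S1` departs from compound 3 by a single change: methyl in place of hydrogen on a saturated ring carbon. Among the compounds with values here, the only measured step, a 4600-fold higher number from compound 1 to compound 2 (3.66 log units; beyond the scatter), is large, but it concerns a group on an aromatic carbon. Within the data shown here, it therefore shows only that values in this assay can move far within this small set, and it gives no size for the methyl change. Among the measured compounds shown here, no measured pair isolates a change on the saturated ring carbon. Compound 1 and compound 2 both carry two methyls on that carbon, yet their values lie far apart, so the two methyls alone do not fix the number. Compound 1, at 1.45 nM, is the closest guide, and it suggests a small move toward a lower number, perhaps within the scatter. The expected move is a 1.7-fold lower number from compound 3 to compound 4 (0.22 log units; within the scatter). For compound 4 the estimated value is 5 nM, with an expected range from 1 nM to 25 nM.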

Compound 4, half-maximal inhibitory concentration: 0.0417 nM
Compound 4: the middle estimate sits 120-fold (2.08 log units) above what was measured, and the stated range ends above it.
By their numbers in this assay, from the lowest: compound 4; then compound 1; then compound 3; then compound 2.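

In this assay, within the data shown here, methyl in place of hydrogen on the saturated ring carbon next to the ring sulfur gives a 200-fold lower number from compound 3 to compound 4 (2.30 log units; beyond the scatter) and is the only change at this position with a measured size. With two methyls on that carbon in each compound, the group on the aromatic carbon still moves the number: trifluoromethyl in place of acetyl gives a 35-fold lower number from compound 1 to compound 4 (1.54 log units; beyond the scatter) and trifluoromethyl in place of acetamido gives a 160000-fold lower number from compound 2 to compound 4 (5.20 log units; beyond the scatter) in the same assay. No evidence available here accounts for the size of the methyl step.

The compounds shown leave open whether an ethyl group or a longer chain on that saturated ring carbon would keep so low a number. They also leave open whether the methyl change would have a similar size with acetyl or acetamido on the aromatic carbon.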